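This account rests on a few compounds, and the source may have more. Where it says the series, first, only, none or still open, it means among the compounds named here.

Measured compounds:
compound 1 `Cc1nc(C#Cc2cncc(Br)c2)cs1` — in a functional assay on CHO cells for agonist activity at metabotropic glutamate receptor 5 (Homo sapiens), read by inositol phosphate accumulation (a higher number here means a weaker inhibitor, a lower number a stronger inhibitor), compound 1 gives 60 nM
compound 2 `Cc1nc(C#Cc2cncc(-c3ccc(F)cc3)c2)cs1` — compound 2 gives 162 nM

Going by the values given here, compound 2 stands at the higher of the two numbers; the only step recorded so far, a 2.7-fold higher number from compound 1 to compound 2 (0.43 log units; beyond the scatter), separates it from compound 1 and lies beyond the scatter.

Compound 3 `COc1ccc(-c2cncc(C#Cc3csc(C)n3)c2)cc1` differs from compound 2 by methoxy in place of fluoro on an aromatic carbon. Among the compounds with values here, no measured step bears directly on this change: the single step available, a 2.7-fold higher number from compound 1 to compound 2 (0.43 log units; beyond the scatter), replaced bromo on the shared core with the whole 4-fluorophenyl group and says nothing about swapping one substituent on that added ring for another. With no guidance from the series, no movement beyond the scatter is expected in this assay; the step of a 1.1-fold higher number from compound 2 to compound 3 (0.05 log units; within the scatter) is set near nil as an expectation. Compound 3 is estimated at 180 nM, with a range of 70 nM to 450 nM.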

Compound 3, half-maximal inhibitory concentration: 225 nM
The estimate for compound 3 lay 1.3-fold (0.10 log units) below the measured number, within the range that was stated.
By their numbers in this assay, from the lowest: compound 1; then compounds 2 and 3 (each within the scatter of the next).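

In this assay the swap of fluoro for methoxy on the added ring is a 1.4-fold higher number from compound 2 to compound 3 (0.14 log units; within the scatter) and so gives no readable difference between compound 2 and compound 3. Going by these compounds alone, this is the first reading of a substituent on that ring, on an aromatic carbon para to a large group, rather than of the ring as a whole, and here methoxy with its two heavy atoms and one hydrogen-bond acceptor cannot be told from fluoro. No measured evidence bears on why these two groups read alike.

Going by these compounds, whether an amine, a carboxylic acid or a longer chain such as butoxy on this same carbon would give a step beyond the scatter remains open. Also open, on these data alone, is whether any group on this ring would give a lower number than compound 2.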